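Swapping the Phenoxy for a Sulfanyl on the Shared Core

This account rests on a few compounds, and the source may have more. Where it says the series, first, only, none or still open, it means among the compounds named here.

Compound 1 `Cc1ccccc1-c1nnc(Nc2nc3ccc(Cl)cc3s2)o1`: 23.9%
Compound 2 `Clc1ccc2nc(Nc3nnc(Oc4ccccc4)o3)sc2c1`: 74.2%

On a functional assay on the whole organism (strain Wistar) for inhibition, with Rattus norvegicus as the target, read by paw edema, with stated times of 1 h and 3 h, at a dose of 70 mg/kg by the oral route (on this read-out lower numbers stand for less inhibition and higher numbers for more inhibition at the one dose given (going by the name of the read-out)), compound 2 gives 74.2%, the highest of the two numbers at hand. Going by the values given here, its only neighbour is compound 1, which gives 23.9%, and the single step between them, a number 50.3 percentage points higher from compound 1 to compound 2 (beyond the scatter), is a large one.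

Compound 3 `Sc1nnc(Nc2nc3ccc(Cl)cc3s2)o1` has not yet been measured. It differs from compound 2 in one place: sulfanyl in place of phenoxy on an aromatic carbon. Among the compounds with values here, no measured step exchanges a phenoxy for a sulfanyl group, so there is no direct guide to this change. Within the data shown here, the one step available bears on it only loosely: it shows that the group on this carbon of the shared core can move the read-out a long way, since exchanging one ring-bearing group for another gave the large difference just named. Removing the ring altogether in favour of a single sulfur is a bigger change still, so a sizeable shift in either direction is possible; the expectation leans toward a loss, with a wide range. Compound 3 is therefore estimated at 40%, between 12% and 68%, an expected step of a number 34.2 percentage points lower from compound 2 to compound 3 (beyond the scatter).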

Compound 3, a percentage reported as inhibition, in the whole organism at one dose (the size of the read-out at that dose, not a potency): 61.7%
The estimate for compound 3 lay 21.7 percentage points below the measured number; the range from low to high includes it.
By their numbers in this assay, from the lowest: compound 1; then compound 3; then compound 2.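

In this assay, a ring on this carbon of the shared core is not needed for a high reading: exchanging phenoxy, with its six-membered aromatic ring, for sulfanyl, which has no ring, gives a number 12.5 percentage points lower from compound 2 to compound 3 (beyond the scatter), a modest step next to the large one seen earlier. Sulfanyl also reads well clear of the ring-bearing 2-methylphenyl group, with a number 37.8 percentage points higher from compound 1 to compound 3 (beyond the scatter), so having a ring at this position does not by itself set the order: compound 2 and compound 1 both carry one and stand at opposite ends, while compound 3 lies in the middle without one. Nothing available here explains why these groups rank in this order.

The compounds shown leave open whether sulfur itself matters at this position, or whether another small group, such as an amine or a hydroxyl group, would read much the same. Sulfanyl also brings a hydrogen-bond donor that phenoxy lacks, and a methoxy group, which has no such donor, would help to show whether that difference counts.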